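The Same Ring Change on Two Different Cores

The source may hold more compounds than are shown below. What is called first, only, known or untested is meant among the compounds shown, and "the series" means these compounds.

Compound 1, `Oc1ccc(O)c(-c2cc(-c3ccc(Cl)cc3)nn2-c2ccccc2)c1`, carries a 2,5-dihydroxyphenyl group on a five-membered aromatic ring with two nitrogens. In a functional assay on cells (Cancer cell lines, Homo sapiens) for cytotoxicity, read by sulforhodamine B assay, with a stated time of 48 h (on this read-out lower numbers stand for stronger inhibition of growth and higher numbers for weaker inhibition of growth), compound 1 gives 32000 nM. Compound 3, `O=C1C=CC(=O)C(c2cc(-c3ccc(Cl)cc3)nn2-c2ccccc2)=C1`, differs from compound 1 in one place only: a group of 8 heavy atoms (6 carbon, 2 oxygen; one six-membered non-aromatic ring of carbon only) in place of a group of 8 heavy atoms (6 carbon, 2 oxygen; one six-membered aromatic ring of carbon only), on an aromatic carbon In this assay compound 3 gives 53300 nM, so the step is a 1.7-fold higher number from compound 1 to compound 3 (0.22 log units; within the scatter).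

Compound 2, `CC(=O)NS(=O)(=O)c1ccc(-n2nc(-c3ccccc3)cc2-c2cc(O)ccc2O)cc1`, sits on another core; the difference between the two cores is not broken down here. In this assay compound 2 gives 100000 nM, the highest of the three numbers, though its gap to compound 3 is within the scatter while its gap to compound 1 lies beyond it.

Compound 4, `CC(=O)NS(=O)(=O)c1ccc(-n2nc(-c3ccccc3)cc2C2=CC(=O)C=CC2=O)cc1`, is not yet measured. It differs from compound 2 by the same kind of change: a group of 8 heavy atoms (6 carbon, 2 oxygen; one six-membered non-aromatic ring of carbon only) in place of a group of 8 heavy atoms (6 carbon, 2 oxygen; one six-membered aromatic ring of carbon only), on an aromatic carbon The surroundings are not identical: in compound 1 the place is next to the ring atom that bears a phenyl group and two ring bonds from the ring atom that bears a 4-chlorophenyl group, whereas in compound 2 it is next to the ring atom that bears a large group and two ring bonds from the ring atom that bears a phenyl group.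

For the measured compounds named here, the step is expected to be a 1.5-fold higher number from compound 2 to compound 4 (0.18 log units; within the scatter), close to the earlier one, because a 1.7-fold higher number from compound 1 to compound 3 (0.22 log units; within the scatter) is the only guide available. Compound 4 is therefore expected to give about 150000 nM in this assay, with a plausible range from 60000 nM to 400000 nM. Since compound 2 already gives a high number, the assay may report only a limit for compound 4.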

Compound 4, concentration for total growth inhibition: 100000 nM
Beside the measured number, compound 4's estimate is 1.5-fold (0.18 log units) above it, within the range that was stated.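

In this assay, for the compounds shown here, putting the non-aromatic ring in place of the 2,5-dihydroxyphenyl group on the second core gives no change at the digits printed from compound 2 to compound 4 (within the scatter), so this swap again produces no step that can be told apart from the scatter. The two cores therefore agree, and in this small set the change carries from one to the other without a detectable difference: the same change on two cores in this assay, a 1.7-fold higher number (0.22 log units; within the scatter) from compound 1 to compound 3 and no change at the digits printed (within the scatter) from compound 2 to compound 4, 1.7-fold (0.22 log units) apart, within the scatter of two such steps. Going by these compounds alone, this agreement rests on only two pairs, and neither step stands clear of the scatter, so it shows that the swap made no measurable difference on these two cores; it does not show that the same would hold on a third core, and it gives no reason why the number stays put.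

The compounds shown leave open how a different group at this place, such as a plain phenyl group, an amine or a carboxylic acid, would compare with the two rings tested here. They also leave open how much each part of the two cores contributes on its own, since the 4-chlorophenyl group and the large group of compound 2 are never varied one at a time.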